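The compounds below may be only part of what the source reports. "The series", "measured", "known", "first", "only" and "open" are said of these compounds alone.

The compounds here share one core and differ in the group on a saturated chain carbon bound to an aromatic nitrogen. They are compound 1 `CCC(C)CCn1nc(-c2cccs2)c(O)c(C2=NS(=O)(=O)c3cc(NS(C)(=O)=O)ccc3N2)c1=O`, compound 2 `COC(C)(C)CCn1nc(-c2cccs2)c(O)c(C2=NS(=O)(=O)c3cc(NS(C)(=O)=O)ccc3N2)c1=O` and compound 3 `CS(=O)(=O)Nc1ccc2c(c1)S(=O)(=O)N=C(c1c(O)c(-c3cccs3)nn(CC3CC3)c1=O)N2`. In an in vitro ADME assay on microsomes from liver (Homo sapiens) for metabolic stability, tested at 5 uM (a higher number here means that the compound lasts longer, a lower number that the compound disappears faster), compound 1 gives > 1 h, which is a limit and not a number. In this assay, compound 2 gives > 1 h, again a limit. In this assay, compound 3 gives > 1 h, also a limit. So compound 3 has no exact position and shares its reading with the others, as the limit of > 1 h in this assay, at which 3 of the 3 values shown sit, shows.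

The next compound is compound 4 `CS(=O)(=O)Nc1ccc2c(c1)S(=O)(=O)N=C(c1c(O)c(-c3cccs3)nn(Cc3ccccc3)c1=O)N2`, and the change is phenyl in place of cyclopropyl on a saturated chain carbon bound to an aromatic nitrogen. In words, a cyclopropylmethyl group gives way to benzyl.

Among the measured compounds shown here, three measured steps bear on this. Two change the group at the same chain carbon: a step that the two limits leave unreadable from compound 1 to compound 3 and a step that the two limits leave unreadable from compound 2 to compound 3. The third changes the chain further out: a step that the two limits leave unreadable from compound 1 to compound 2. None of them has a readable size, so they offer no direction, and none involves a phenyl group. With nothing pointing either way, no change beyond the usual scatter is expected.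

The expected change is a step that the limit leaves unreadable from compound 3 to compound 4. The half-life estimated for compound 4 is 1.3 h, with an expected range from 0.5 h to 3 h.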

Compound 4, half-life: > 1 h
Compound 4 gave a limit, no number; the forecaster's own chance of this, stated with the estimate: 70%; the middle value lies beyond the limit too.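

Compound 4 also gives a limit and not a number, so its steps from compound 1, compound 2 and compound 3 cannot be read, and all the compounds share one reading: the limit of > 1 h in this assay, at which 4 of the 4 values shown sit. The compounds shown leave open whether benzyl, cyclopropylmethyl or the two longer chains differ at all in this assay.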